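The source may hold more compounds than are shown below. What is called first, only, known or untested is meant among the compounds shown, and "the series" means these compounds.

For the measured compounds named here, compound 2 `CN1C(=O)C(CCO)COC12C=CC(=O)C=C2` is one of two compounds measured in an assay on isolated protein for inhibition of N-lysine methyltransferase SMYD2 (Homo sapiens), read by filter binding, with a stated time of 1 h; on this read-out higher numbers stand for weaker inhibition and lower numbers for stronger inhibition. Its value there is a limit of the assay rather than a number: compound 2 gives > 30000 nM, matching (the limit of > 30000 nM in this assay, at which 1 of the 2 values shown sits). Compound 1 `CC(C)N1C(=O)C(Cc2ccc(C(F)(F)F)cc2)COC12C=CC(=O)C=C2` likewise sits at a limit, giving > 20000 nM in this assay, matching (the limit of > 20000 nM in this assay, at which 1 of the 2 values shown sits). Compound 3 `CN1C(=O)C(CCNc2ccccc2)COC12C=CC(=O)C=C2` differs from compound 2 by anilino in place of hydroxy on a saturated chain carbon, two bonds along the chain from a saturated ring carbon. Going by the values given here, with only limits available, no measured step gives a size or direction. Compound 3 is expected to give 15000 nM, within 3000 nM to 50000 nM. That expected value means a step of an at least 2.0-fold lower number from compound 2 to compound 3 (0.30 log units; that floor lies within the scatter).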

Compound 3, half-maximal inhibitory concentration: > 20000 nM
Compound 3 was reported as a limit; the forecaster's own chance of this, stated with the estimate: 60%; middle value at least 1.3-fold (0.12 log units) away from the limit.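

In this assay compound 3 gives > 20000 nM, a limit of the assay. For the compounds shown here, compound 2 gives > 30000 nM, also a limit, so no step from compound 2 to compound 3 can be read. The compounds shown leave open whether any group on this chain gives a measurable value in this assay.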